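Aryl swap on the triazole nitrogen within the quinoline ether series

The compounds below may be only part of what the source reports. "The series", "measured", "known", "first", "only" and "open" are said of these compounds alone.

Among the measured compounds shown here, compound 3 `COc1cc2c(Oc3ccc(NC(=O)c4nnn(-c5ccccc5Cl)c4C(F)(F)F)cc3F)ccnc2cc1OCCCN1CCN(C)CC1` gives the lowest number of the three measured so far: in a functional assay on HT-29 cells (Homo sapiens) for cytotoxicity, read by MTT assay, with a stated time of 72 h (on this read-out lower numbers stand for stronger inhibition and higher numbers for weaker inhibition), compound 3 gives 270 nM. For the measured compounds named here, compound 1 `COc1cc2c(Oc3ccc(NC(=O)c4nnn(-c5ccc(C)cc5)c4C(F)(F)F)cc3F)ccnc2cc1OCCCN1CCCC1` gives 550 nM in this assay, and compound 2 `COc1cc2c(Oc3ccc(NC(=O)c4nnn(-c5ccc(C)cc5)c4C(F)(F)F)cc3F)ccnc2cc1OCCCN1CCC(C)CC1` gives 1200 nM; the single measured step, a 2.2-fold higher number from compound 1 to compound 2 (0.34 log units; beyond the scatter), sits at the amine end of the chain and does not touch the aryl group of interest. Compound 4 `COc1cc2c(Oc3ccc(NC(=O)c4nnn(-c5ccc(C)cc5)c4C(F)(F)F)cc3F)ccnc2cc1OCCCN1CCN(C)CC1` differs from compound 3 by 4-methylphenyl in place of 2-chlorophenyl on an aromatic nitrogen. Going by the values given here, no measured pair isolates this change: compounds 1 and 2 carry 4-methylphenyl but also differ from compound 3 at the amine, so their values show only that 4-methylphenyl analogues in this assay lie in the same broad range. Among the compounds with values here, with no direct precedent, the step from compound 3 to compound 4 is expected to be small or within the scatter, if anything toward a higher number, which is a 1.5-fold higher number from compound 3 to compound 4 (0.17 log units; within the scatter). For compound 4 the expected value in this assay is therefore 400 nM, with a range from 180 nM to 900 nM.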

Compound 4, half-maximal inhibitory concentration: 1170 nM
Estimate against measurement, compound 4: 2.9-fold (0.47 log units) below, outside the stated range (above it).
By their numbers in this assay, from the lowest: compound 3; then compound 1; then compounds 4 and 2 (each within the scatter of the next).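

In this assay the change to 4-methylphenyl from 2-chlorophenyl, with the amine held constant, gives a 4.3-fold higher number from compound 3 to compound 4 (0.64 log units; beyond the scatter) and shows that the aryl group on this aromatic nitrogen can shift the number beyond the scatter. Among the 4-methylphenyl compounds, the amine steps are a 1.0-fold lower number from compound 2 to compound 4 (0.01 log units; within the scatter) and a 2.1-fold higher number from compound 1 to compound 4 (0.33 log units; beyond the scatter) and, with 4-methylpiperazin-1-yl present in compound 4 as well, the low number of compound 3 cannot be credited to that amine alone. No evidence here bears on the origin of the aryl step.

Among the compounds shown here, only one pair isolates the aryl change, so the roles of the chlorine and the methyl, and of their ring placement, remain unseparated. Data on 4-chlorophenyl and 2-methylphenyl would separate them, and a 2-chlorophenyl analogue carrying pyrrolidin-1-yl would test whether the step holds with another amine.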